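Removing One Hydroxy From a Catechol-Bearing Dienone

The source may report more compounds than this note shows. Statements on the series, on what has been measured and on what is new or still open speak of the compounds shown alone.

Measured compounds:
compound 1, `O=C1/C(=C/c2ccccc2)CCC/C1=C\c1ccc(O)c(O)c1`, 90.7%
compound 2, `O=C(/C=C(O)/C=C/c1cc(O)ccc1O)c1cc(O)ccc1O`, 96.9%
compound 3, `O=C(/C=C(O)/C=C/c1ccc(O)c(O)c1)c1cc(Cl)ccc1O`, 85.6%

Of the compounds shown here, three have been tested in an assay on isolated protein for inhibition of Alpha glucosidase (Homo sapiens), with stated times of 5 min and 15 min, tested at 50 uM; on this read-out lower numbers stand for less inhibition and higher numbers for more inhibition at the one concentration tested (going by the name of the read-out). Compound 1 gives 90.7%, compound 2 gives 96.9% and compound 3 gives 85.6%. Compound 1 stands second of the three, but its distance to compound 3 and its distance to compound 2 both lie within the usual scatter, so the three numbers cannot be ranked against each other with any confidence; all three sit in the upper part of the scale.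

Compound 4, `O=C1/C(=C/c2ccccc2)CCC/C1=C\c1ccc(O)cc1`, has not yet been measured. It differs from compound 1 in one place: hydrogen in place of hydroxy on an aromatic carbon. The hydroxy that leaves sits ortho to a hydroxy group and meta to a large group, so the two neighbouring hydroxy groups of compound 1 become a single hydroxy in compound 4.

Going by the values given here, no step between measured compounds covers this change, so the expectation rests on the high starting point of compound 1 in this assay and on the loss of one hydroxy. A fall beyond the scatter is expected, though not a collapse: the step of a number 18.7 percentage points lower from compound 1 to compound 4 (beyond the scatter) is the estimated size. Compound 4 is therefore expected to give about 72%, with a range from 48% to 90%.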

Compound 4, a percentage reported as inhibition, at one concentration (the size of the read-out at that concentration, not a potency): 53%
Compound 4: the middle estimate sits 19 percentage points above what was measured; the range from low to high includes it.
By their numbers in this assay, from the lowest: compound 4; then compounds 3, 1 and 2 (each within the scatter of the next, the first and the last beyond it).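

Going by these compounds alone, replacing the hydroxy with hydrogen gives a number 37.7 percentage points lower from compound 1 to compound 4 (beyond the scatter) in this assay, the first step in this set that can be read across a change in one place, and it shows that this aromatic carbon, ortho to a hydroxy group and meta to a large group, is not indifferent to what it carries. The earlier compounds shown here, which have no single-place step among them, could not tie any of their high numbers to one group; here the loss of this hydroxy alone lowers the number by a large step, although compound 4 still gives 53%, so inhibition at the one concentration tested does not vanish with it. Nothing at hand explains the fall.

The compounds shown leave open whether a hydroxy is specifically required on this carbon, or whether a methoxy group, a fluorine atom or an amine there would hold the number nearer to that of compound 1. They also leave open what removing the other hydroxy instead would do, and whether the same change would give a step of similar size on the cores of compound 2 or compound 3.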